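Trimming a benzyl group to ethyl: expected loss of cytotoxicity

A few compounds are considered here, and "the series" means these few. Any claim that something is new, unique, unknown or untested is made for them only; others in the source may bear on it.

Measured compounds:
compound 1 `O=C(O)CN1C(=O)/C(=C/c2nc3ccccc3n2Cc2ccc(Br)cc2)SC1=S`: 9120 nM
compound 2 `O=C(O)CN1C(=O)/C(=C/c2nc3ccccc3n2Cc2ccc([N+](=O)[O-])cc2)SC1=S`: 11400 nM
compound 3 `O=C(O)CN1C(=O)/C(=C/c2nc3ccccc3n2Cc2ccc(C(F)(F)F)cc2)SC1=S`: 25300 nM

In a functional assay on A549 cells (Homo sapiens) for cytotoxicity, read by MTT assay, with a stated time of 48 h (a lower number here means a stronger inhibitor, a higher number a weaker inhibitor), compound 1 gives the lowest of the three numbers, with compound 2 within the scatter of it and compound 3 modestly higher a 2.8-fold higher number from compound 1 to compound 3 (0.44 log units; beyond the scatter). Compound 4 `CCn1c(/C=C2\SC(=S)N(CC(=O)O)C2=O)nc2ccccc21` differs from compound 1 by methyl in place of 4-bromophenyl on a saturated chain carbon bound to an aromatic nitrogen. The measured steps swap one group on the 4-bromophenyl ring for another (a 1.3-fold higher number from compound 1 to compound 2 (0.10 log units; within the scatter), a 2.2-fold higher number from compound 2 to compound 3 (0.35 log units; beyond the scatter)); none removes that ring, so they bear only loosely on this change. A whole aromatic ring leaves, and for cytotoxicity such a loss usually gives a higher number. The expected step is a 2.4-fold higher number from compound 1 to compound 4 (0.38 log units; beyond the scatter). Compound 4 is therefore estimated at 22000 nM, within 7000 nM to 70000 nM.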

Compound 4, half-maximal inhibitory concentration: 9440 nM
Compound 4: middle estimate off by 2.3-fold (0.37 log units), on the high side; the range from low to high includes it.
By their numbers in this assay, from the lowest: compounds 1, 4 and 2 (each within the scatter of the next); then compound 3.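

In this assay the 4-bromophenyl group on this saturated chain carbon can give way to methyl with a 1.0-fold higher number from compound 1 to compound 4 (0.01 log units; within the scatter) and the same holds for the 4-nitrophenyl group with a 1.2-fold lower number from compound 2 to compound 4 (0.08 log units; within the scatter) so the number stays level in both. Only the 4-(trifluoromethyl)phenyl pair shows a real gap, with a 2.7-fold lower number from compound 3 to compound 4 (0.43 log units; beyond the scatter) and there the smaller group gives the lower number. Among these compounds, then, the whole aromatic ring is not needed for this cytotoxicity. On these data alone, whether a longer chain such as butyl, or a chain ending in an amine, would keep this level remains open. What lies behind the result also stays open, and no measurement here bears on it.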